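Chloro for methoxy on the aryl piperazine of a succinimide amide

The source may hold more compounds than are shown below. What is called first, only, known or untested is meant among the compounds shown, and "the series" means these compounds.

Measured compounds:
Compound 1, `CCC(C(=O)N1CCN(c2cccc(Cl)c2)CC1)N1C(=O)CCC1=O`: 100%
Compound 2, `COc1cccc(N2CCN(C(=O)C(C)N3C(=O)CCC3=O)CC2)c1`: 0%

In a functional assay on the whole organism (strain Swiss) with Mus musculus as the target, in the maximal electroshock model, with a stated time of 1 h, at a dose of 300 mg/kg by the intraperitoneal route (on this read-out lower numbers stand for a weaker effect and higher numbers for a stronger effect at the one dose given), compound 1 gives 100%. Compound 2, which carries a methoxy group on the phenyl ring, gives 0% in this assay, the lowest of the two numbers shown, and the gap between compound 2 and compound 1 lies beyond the usual scatter of such measurements.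

Compound 3, `CC(C(=O)N1CCN(c2cccc(Cl)c2)CC1)N1C(=O)CCC1=O`, has not yet been tested in this assay. It differs from compound 2 in one place: chloro in place of methoxy on an aromatic carbon. Among the compounds with values here, the only measured compound that also carries a chloro group on its phenyl ring is compound 1, and its full response stands in contrast to the silence of compound 2.

Because compound 1 gives 100% while compound 2 gives 0%, the expected step from compound 2 to compound 3 in this assay is upward and large, well beyond the scatter, at a number 60 percentage points higher from compound 2 to compound 3 (beyond the scatter). For compound 3 in this assay an estimated response of 60% is expected, with a range from 20% to 100%.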

Compound 3, a percentage reported as activity, at one dose (the size of the read-out at that dose, not a potency): 75%
The estimate for compound 3 lay 15 percentage points below the measured number; the range from low to high includes it.
By their numbers in this assay, from the lowest: compound 2; then compound 3; then compound 1.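

In this assay, the change from 3-methoxyphenyl to 3-chlorophenyl, with the rest of the molecule held constant, gives a number 75 percentage points higher from compound 2 to compound 3 (beyond the scatter), so this one replacement on an aromatic carbon, meta to a large group, is enough to separate a silent compound from a clearly active one. Compounds 1 and 2 could not show this on their own, as they differ in two places, and the chloro group and the chain were not separated until compound 3 supplied a link to each. The second link shows that the chain also counts once the chloro group is fixed: hydrogen in place of methyl on a saturated chain carbon, two bonds along the chain from an amide-type nitrogen in a ring and a carbonyl carbon, gives a number 25 percentage points lower from compound 1 to compound 3 (beyond the scatter), a modest step, and nothing measured here accounts for either step.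

The compounds shown leave open whether a fluoro, methyl or trifluoromethyl group on the same aromatic carbon would behave like chloro or like methoxy, and whether a longer chain would carry the read-out further or reverse it. They also leave open whether the methoxy compound would stay silent with the chain of compound 1, and a read-out at one dose cannot settle how potent any of these compounds is.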